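Cytotoxicity of pyrazinoyl hydrazones on mouse macrophages

This account rests on a few compounds, and the source may have more. Where it says the series, first, only, none or still open, it means among the compounds named here.

Compound 1 `O=C(N/N=C/c1cccc(Cl)c1)c1cnccn1`: 100%
Compound 2 `O=C(N/N=C/c1ccc(Br)cc1)c1cnccn1`: 100%
Compound 3 `O=C(N/N=C/c1ccccc1O)c1cnccn1`: 1%

Three hydrazones on a shared core were tested in an ADME assay on J774 cells (Mus musculus) for cytotoxicity, read by MTT assay, with a stated time of 48 h, tested at 50 ug/mL; a higher number here means a weaker effect of the compound at the concentration tested, a lower number a stronger effect. Compound 1 gives 100%, and compound 2 gives 100%, the two being level at the digits printed and together the highest of the three numbers. Compound 3 stands far apart with 1%, a number well beyond the scatter below the other two. Within the data shown here, no step between compounds differing in one place is available, so the two values of compound 1 and compound 3 are simply recorded as they are.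

The next compound, compound 4 `O=C(N/N=C/c1cccc([N+](=O)[O-])c1)c1cnccn1`, differs from compound 1 as follows: nitro in place of chloro on an aromatic carbon. Since compound 1 gives 100% and compound 2 gives 100%, both halogen-bearing analogues leaving the cells untouched, the expected step for a number 10 percentage points lower from compound 1 to compound 4 (within the scatter) is none beyond the scatter, or at most a small move downward. Compound 4 is therefore estimated at 90%, with a range from 60% to 100%.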

Compound 4, a percentage reported as activity, at one concentration (the size of the read-out at that concentration, not a potency): 100%
Estimate against measurement, compound 4: 10 percentage points below; low and high end bracket the measured number.
By their numbers in this assay, from the lowest: compound 3; then compounds 1, 2 and 4 (each within the scatter of the next).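

In this assay the step reads no change at the digits printed from compound 1 to compound 4 (within the scatter), so on this aromatic carbon, meta to a large group, nitro in place of chloro leaves the read-out unchanged. The earlier compounds shown here showed this high number only with a halogen on the ring; compound 4 shows that it also holds with a group carrying no halogen, with more heavy atoms and with two hydrogen-bond acceptors where chloro has none. No measurement at hand gives a reason for this sameness.

As far as these compounds go, whether an amine or a carboxylic acid on this same carbon would keep the number remains open. Also open is what sets compound 3 apart at 1%, as no compound shown differs from it in only one place.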